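Swapping a pyridinyl ether for a chlorophenyl ether

The source may hold more compounds than are shown below. What is called first, only, known or untested is meant among the compounds shown, and "the series" means these compounds.

Of the compounds shown here, three have been tested in an ADME assay on PBMC cells (Homo sapiens) for cytotoxicity; on this read-out higher numbers stand for lower toxicity in this test and lower numbers for higher toxicity in this test. Compound 1 `COc1cccc(OC(c2ccc(C(F)(F)F)cc2)C2CCN(C(C)CCNC(=O)c3c(Cl)cncc3Cl)CC2)n1` gives 32700 nM. Compound 3 `CC(CCNC(=O)c1c(Cl)cncc1Cl)N1CCC(C(Oc2ccncc2)c2ccc(Br)cc2)CC1` gives 31200 nM, a value within the scatter of compound 1. Compound 2 `CCO/N=C(/c1ccc(Br)cc1)C1CCN(C(C)CNC(=O)c2c(C)cc[n+]([O-])c2C)CC1` gives 182000 nM, beyond the scatter above compound 1, so compound 1 stands second highest of the three numbers. Compound 4 `CC(CCNC(=O)c1c(Cl)cncc1Cl)N1CCC(C(Oc2cccc(Cl)c2)c2ccc(C(F)(F)F)cc2)CC1` has not yet been measured in this assay. It differs from compound 1 in one place: 3-chlorophenyl in place of 6-methoxypyridin-2-yl on an oxygen on a saturated carbon. Within the data shown here, no measured pair shows this exact change, so the expectation rests on the closeness of compound 1 and compound 3, which differ at the same oxygen yet agree within the scatter. The step from compound 1 to compound 4 is estimated as a 1.2-fold lower number from compound 1 to compound 4 (0.08 log units; within the scatter), none beyond the scatter. Compound 4 is expected at 27000 nM, between 9000 nM and 80000 nM.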

Compound 4, half-maximal cytotoxic concentration: 8100 nM
Compound 4: middle estimate off by 3.3-fold (0.52 log units), on the high side; the whole stated range lies above it.
By their numbers in this assay, from the lowest: compound 4; then compounds 3 and 1 (each within the scatter of the next); then compound 2.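

Putting 3-chlorophenyl in place of 6-methoxypyridin-2-yl on this oxygen gives a 4.0-fold lower number from compound 1 to compound 4 (0.61 log units; beyond the scatter) in this assay and so means higher toxicity in this test. Among these compounds, this is the first step here with only one place changed, and it shows that the group on this oxygen can move the number beyond the scatter. Nothing at hand explains this step.

On these data alone, it stays open whether the ring nitrogen, the methoxy or the chlorine matters most. A plain phenyl or a 3-methoxyphenyl on this oxygen would help separate them.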